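The source may report more compounds than this note shows. Statements on the series, on what has been measured and on what is new or still open speak of the compounds shown alone.

Compound 1 `CN(C)C(=O)c1ccncc1Nc1cc(-c2ccc3ccn(C)c3c2)c2nccnc2c1` gives 499 nM in an assay for inhibition of 6-phosphofructo-2-kinase/fructose-2,6-bisphosphatase 3 (Homo sapiens), read by ADP-Glo, with a stated time of 2 h; on this read-out lower numbers stand for stronger inhibition and higher numbers for weaker inhibition.
Compound 2 `CN1CCC(NC(=O)c2ccncc2Nc2cc(-c3ccc4ccn(C)c4c3)c3nccnc3c2)CC1` gives 38 nM in this assay.
Compound 3 `CN1CC(NC(=O)c2ccncc2Nc2cc(-c3ccc4ccn(C)c4c3)c3nccnc3c2)C1` gives 30 nM in this assay.

Compound 3 has the lowest number of the three, but compound 2 sits within the scatter of it (a 1.3-fold lower number from compound 2 to compound 3 (0.10 log units; within the scatter)), and only compound 1 stands clearly apart (a 17-fold lower number from compound 1 to compound 3 (1.22 log units; beyond the scatter)). Compound 4 `CN1CCC(N(C)C(=O)c2ccncc2Nc2cc(-c3ccc4ccn(C)c4c3)c3nccnc3c2)C1` differs from compound 3 in one place: methyl(1-methylpyrrolidin-3-yl)amino in place of (1-methylazetidin-3-yl)amino on a carbonyl carbon. Among the measured compounds shown here, two measured steps bear on this change. Both a 13-fold lower number from compound 1 to compound 2 (1.12 log units; beyond the scatter) and a 17-fold lower number from compound 1 to compound 3 (1.22 log units; beyond the scatter) show a large gain when dimethylamino on the carbonyl carbon was replaced by an amino group carrying a nitrogen-containing ring, and the ring size mattered little (a 1.3-fold lower number from compound 2 to compound 3 (0.10 log units; within the scatter)). Compound 4 keeps such a ring but loses the hydrogen-bond donor of compound 3, so a moderate rise, a 3.3-fold higher number from compound 3 to compound 4 (0.52 log units; beyond the scatter), is expected. Compound 4 is expected to give 100 nM in this assay, between 30 nM and 400 nM.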

Compound 4, half-maximal inhibitory concentration: 176 nM
Estimate against measurement, compound 4: 1.8-fold (0.25 log units) below; measured number inside the range.
By their numbers in this assay, from the lowest: compounds 3 and 2 (each within the scatter of the next); then compound 4; then compound 1.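

The ring-bearing group on the carbonyl carbon keeps part of its gain over dimethylamino even without the amide hydrogen (a 2.8-fold lower number from compound 1 to compound 4 (0.45 log units; beyond the scatter)), so that hydrogen is not needed for all of the gain. Yet this group falls short of the two ring-bearing groups that keep that hydrogen (a 5.9-fold higher number from compound 3 to compound 4 (0.77 log units; beyond the scatter)) and (a 4.6-fold higher number from compound 2 to compound 4 (0.67 log units; beyond the scatter)). Nothing measured here gives a reason for these steps.

Compound 4 changes the ring size and adds the methyl on the amide nitrogen together, so their shares cannot be told apart. The (1-methylpyrrolidin-3-yl)amino group, which has the five-membered ring and keeps the amide hydrogen, would separate them.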